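Replacing the ethenyl arm of compound 2

The source may report more compounds than this note shows. Statements on the series, on what has been measured and on what is new or still open speak of the compounds shown alone.

compound 1 `C=C1C(=O)O[C@H]2CC3=C[C@H](C/C(C)=C/[C@@H](OC(=O)c4ccc(-c5ccccc5)cc4)[C@H]12)OC3=O`: 3500 nM
compound 2 `C=C1C(=O)O[C@H]2CC3=C[C@H](C/C(C)=C/[C@@H](OC(=O)/C=C/c4ccc(N(C)C)cc4)[C@H]12)OC3=O`: 1300 nM
compound 3 `C=C1C(=O)O[C@H]2CC3=C[C@H](C/C(C)=C/[C@@H](OC(=O)/C=C/c4ccc(C(F)(F)F)cc4)[C@H]12)OC3=O`: 1400 nM

All three were measured in a functional assay on NCI-H460 cells (Homo sapiens) for cytotoxicity, read by MTT assay, with a stated time of 48 h; a higher number here means a weaker inhibitor, a lower number a stronger inhibitor. Compound 2 gives 1300 nM, the lowest number shown, though level within the scatter with compound 3 . Compound 1 gives the clearly higher 3500 nM.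

Compound 4 `C=C1C(=O)O[C@H]2CC3=C[C@H](C/C(C)=C/[C@@H](OC(=O)CC4CCCCC4)[C@H]12)OC3=O` has cyclohexylmethyl in place of 2-(4-(dimethylamino)phenyl)ethenyl on a carbonyl carbon. Going by the values given here, the only measured step, a 1.1-fold higher number from compound 2 to compound 3 (0.03 log units; within the scatter), changes a group on an aromatic carbon and stayed within the scatter, but no measured step removes the aromatic ring. A small rise with wide uncertainty is therefore expected. The expected change is a 1.5-fold higher number from compound 2 to compound 4 (0.19 log units; within the scatter). For compound 4 the estimated value is 2000 nM, with an expected range of 800 nM to 5000 nM.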

Compound 4, half-maximal inhibitory concentration: 2000 nM
Beside the measured number, compound 4's estimate shows no gap at the digits printed; low and high end bracket the measured number.
By their numbers in this assay, from the lowest: compounds 2, 3, 4 and 1 (each within the scatter of the next, the first and the last beyond it).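

In this assay, putting cyclohexylmethyl in place of 2-(4-(dimethylamino)phenyl)ethenyl on this carbonyl carbon gave a 1.5-fold higher number from compound 2 to compound 4 (0.19 log units; within the scatter). Going by these compounds alone, the aromatic ring, the double bond outside it and the nitrogen therefore all left in one change without a step beyond the scatter, something the earlier compounds could not show, since all of them keep an aromatic ring here. No evidence is available that explains this result. The compounds shown leave open whether a straight alkyl chain without any ring, or an amine or carboxylic acid on the cyclohexylmethyl group, would stay within that scatter.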